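The source may report more compounds than this note shows. Statements on the series, on what has been measured and on what is new or still open speak of the compounds shown alone.

Among the measured compounds shown here, compound 2 `Cc1ccc(S(=O)(=O)N2CCOCC2)cc1C#Cc1cc(Cl)ccc1OCC(=O)O` holds the lowest of the two numbers so far in an assay on CHO cells for displacement of a labelled ligand from prostaglandin D2 receptor 2 (Homo sapiens), read by scintillation counting; a lower number here means a stronger inhibitor, a higher number a weaker inhibitor; compound 2 gives 3.6 nM. Its nearest neighbour is compound 1 `CCS(=O)(=O)c1ccc(C)c(C#Cc2cc(Cl)ccc2OCC(=O)O)c1`, which in this assay gives 8.6 nM; the change from ethyl to morpholin-4-yl on the sulfonyl sulfur brought a 2.4-fold lower number from compound 1 to compound 2 (0.38 log units; beyond the scatter).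

Compound 3 `CNS(=O)(=O)c1ccc(C)c(C#Cc2cc(Cl)ccc2OCC(=O)O)c1` takes the next step at the same place: methylamino in place of morpholin-4-yl on a sulfonyl sulfur. For the measured compounds named here, no measured pair shows exactly this exchange, so the only step that bears on it is the one from compound 1 to compound 2, which was modest and showed that the group on the sulfonyl sulfur can move the number beyond the scatter without changing it greatly. With compound 3 the group on that sulfur shrinks again from a ring to a two-atom chain, so a return toward the number of compound 1 is expected rather than a further fall. Compound 3 is therefore estimated to give 6.5 nM, within 2.5 nM to 16 nM, which is expected to mean a 1.8-fold higher number from compound 2 to compound 3 (0.26 log units; within the scatter).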

Compound 3, inhibition constant: 10 nM
Compound 3: the middle estimate sits 1.5-fold (0.19 log units) below what was measured; the range from low to high includes it.
By their numbers in this assay, from the lowest: compound 2; then compounds 1 and 3 (each within the scatter of the next).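

In this assay, the exchange of morpholin-4-yl for methylamino on the sulfonyl sulfur gave a 2.8-fold higher number from compound 2 to compound 3 (0.44 log units; beyond the scatter) and so undid the gain that the ring had brought, while the exchange of ethyl for methylamino gave a 1.2-fold higher number from compound 1 to compound 3 (0.07 log units; within the scatter) and left those two compounds without any order between them. Of the three groups now seen at this place, morpholin-4-yl alone stands apart, and the two without a ring cannot be told apart in this assay, even though one is attached through carbon and the other through nitrogen. The step from compound 2 to compound 3 removes the ring and its hydrogen-bond acceptor and brings in a hydrogen-bond donor all at once, and nothing available here accounts for its size or separates these contributions.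

The compounds shown leave open whether another ring on the sulfur, such as piperidin-1-yl or piperazin-1-yl, would share the lower number of compound 2, which would show whether the ring oxygen matters. They also leave open whether dimethylamino, or a longer chain on the nitrogen such as propylamino, would stay level with methylamino.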